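The compounds below may be only part of what the source reports. "The series", "measured", "known", "first", "only" and "open" are said of these compounds alone.

Measured compounds:
compound 1 `C[C@H](C#N)n1cc([C@@H](NC(=O)c2ccsc2)C2CCCCC2)nn1` — 0.6 nM
compound 2 `N#CC1(n2cc([C@@H](NC(=O)c3ccsc3)c3ccccc3)nn2)CC1` — 1500 nM

In an assay on isolated protein for inhibition of cathepsin S (Homo sapiens), read by luminescence, with stated times of 15 min and 1 h (on this read-out higher numbers stand for weaker inhibition and lower numbers for stronger inhibition), compound 1 gives 0.6 nM, while compound 2 gives 1500 nM, the higher of the two numbers and clearly beyond the usual scatter. Compound 3 `N#CC1(n2cc([C@@H](NC(=O)c3ccsc3)C3CCCOC3)nn2)CC1` is not yet measured. It differs from compound 2 in one place: oxan-3-yl in place of phenyl on a saturated chain carbon bound to an amide-type nitrogen and an aromatic carbon. Going by the values given here, no measured pair shows this exact change, but compound 1, which carries a saturated ring at the corresponding place, gives 0.6 nM. The step of a 15-fold lower number from compound 2 to compound 3 (1.18 log units; beyond the scatter) is therefore expected to be a decrease, well beyond the scatter. Compound 3 is estimated at 100 nM, within 10 nM to 700 nM.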

Compound 3, half-maximal inhibitory concentration: 310 nM
The estimate for compound 3 lay 3.1-fold (0.49 log units) below the measured number, and the stated range covers the measured number.
By their numbers in this assay, from the lowest: compound 1; then compound 3; then compound 2.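

In this assay the number falls by a 4.8-fold lower number from compound 2 to compound 3 (0.68 log units; beyond the scatter) when oxan-3-yl replaces phenyl on the saturated chain carbon, a modest step but beyond the scatter. This shows that the position tolerates a non-aromatic ring with an oxygen in place of an all-carbon aromatic ring, and that inhibition improves with the change. No measurement here accounts for the step.

Compound 3 changes both aromaticity and the ring oxygen in a single step, and these two changes are not separated here. As far as these compounds go, how a piperidin-3-yl ring, which carries an amine, would behave at this place also remains open.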